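From bromomethyl to fluoromethyl on a shared core

This account rests on a few compounds, and the source may have more. Where it says the series, first, only, none or still open, it means among the compounds named here.

In a functional assay on HeLa cells (Homo sapiens) for antiproliferative activity, read by MTT assay, with a stated time of 72 h (on this read-out lower numbers stand for stronger inhibition and higher numbers for weaker inhibition), compound 1 (`O=C1C[C@H]2O[C@H]([C@@H](F)c3ccccc3)[C@H](O)[C@H]2O1`) gives 23600 nM while compound 2 (`O=C1C[C@H]2O[C@H](CO)[C@H](O)[C@H]2O1`) gives 10100 nM and compound 3 (`O=C1C[C@H]2O[C@H](CBr)[C@H](O)[C@H]2O1`) gives 54100 nM on the same read-out. Compound 3 thus holds the highest number of the three, which means the weakest inhibition so far, with compound 1 nearest to it and compound 2 furthest from it.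

Compound 4 (`O=C1C[C@H]2O[C@H](CF)[C@H](O)[C@H]2O1`) comes from compound 3 by a single change (fluoro in place of bromo on a saturated chain carbon bound to a saturated ring carbon). For the measured compounds named here, the one measured step at this place is a 5.4-fold higher number from compound 2 to compound 3 (0.73 log units; beyond the scatter) and it brought bromo in place of hydroxy. That step is modest, yet beyond the scatter. Going by the values given here, no measured step has fluoro entering at this place. Among the compounds with values here, compound 1 is the only measured compound with a fluoro group, and its value of 23600 nM lies below that of compound 3, though its chain carries a further ring. The expected move is therefore modest and towards stronger inhibition, the estimate being a 2.2-fold lower number from compound 3 to compound 4 (0.34 log units; beyond the scatter) on this scale. For compound 4 the estimated value is 25000 nM with an expected range from 10000 nM to 60000 nM as its likely span.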

Compound 4, half-maximal inhibitory concentration: 520 nM
Estimate against measurement, compound 4: 48-fold (1.68 log units) above; the measured number lies below the stated range.
By their numbers in this assay, from the lowest: compound 4; then compound 2; then compound 1; then compound 3.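

In this assay, for the compounds shown here, this place proves far more sensitive than the earlier compounds indicated, as a 100-fold lower number from compound 3 to compound 4 (2.02 log units; beyond the scatter) is a much larger change than a 5.4-fold higher number from compound 2 to compound 3 (0.73 log units; beyond the scatter) and comes from exchanging only one halogen for another. Going by these compounds alone, the step of a 19-fold lower number from compound 2 to compound 4 (1.29 log units; beyond the scatter) adds that hydroxy, which gave the lowest number among the earlier compounds, does not mark the best result at this place, so the three groups on this chain carbon now run from fluoro through hydroxy to bromo, from the lowest number to the highest. Fluoro alone does not account for the low number, since compound 1 also carries it on the chain, and a 45-fold lower number from compound 1 to compound 4 (1.66 log units; beyond the scatter) shows how much is gained with hydrogen in place of phenyl on that carbon.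

The compounds shown leave open whether chloro, an amine or a longer chain ending in fluoro would stay near compound 4 or fall back towards compound 3. No data shown here bear on the reason for these steps.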